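Sulfamoyl variation: from piperidin-1-yl to dipropylamino

This account rests on a few compounds, and the source may have more. Where it says the series, first, only, none or still open, it means among the compounds named here.

Within the data shown here, compound 3 `CCOC(=O)[C@@H]1CCCN(S(=O)(=O)c2ccc(S(=O)(=O)N3CCCCC3)cc2)C1` carries piperidin-1-yl on one sulfonyl sulfur; in a functional assay on MIA PaCa-2 cells (Homo sapiens) for inhibition, read by MTT assay, with a stated time of 7 days (a lower number here means a stronger inhibitor, a higher number a weaker inhibitor), compound 3 gives 2900 nM, the highest of the three numbers known so far. Compound 1 `CCOC(=O)[C@@H]1CCCN(S(=O)(=O)c2ccc(S(=O)(=O)N(CC)C(C)C)cc2)C1`, which differs only in bearing ethyl(isopropyl)amino at that sulfur, gives 1000 nM in this assay; the step of a 2.9-fold higher number from compound 1 to compound 3 (0.46 log units; beyond the scatter) lies beyond the scatter. Compound 2 `CCN(CC)S(=O)(=O)c1ccc(S(=O)(=O)N2CCC[C@@H](C(=O)N3CC4(CCN(C(=O)OC(C)(C)C)C4)C3)C2)cc1` differs from compound 3 in several positions at once, so no single-point comparison to compound 3 exists for it; in this assay compound 2 gives 190 nM.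

Compound 4 `CCCN(CCC)S(=O)(=O)c1ccc(S(=O)(=O)N2CCC[C@@H](C(=O)OCC)C2)cc1` differs from compound 3 by dipropylamino in place of piperidin-1-yl on a sulfonyl sulfur. Among the measured compounds shown here, the only step that bears on this change is a 2.9-fold higher number from compound 1 to compound 3 (0.46 log units; beyond the scatter), in which an acyclic dialkylamino group was exchanged for the ring and the number rose. Going back to an acyclic group, here dipropylamino, is expected to bring this assay back toward the level of compound 1, a modest step toward lower numbers. For compound 4 the expected step is a 1.9-fold lower number from compound 3 to compound 4 (0.29 log units; within the scatter). The estimate for compound 4 in this assay is 1500 nM, with a range from 600 nM to 4000 nM.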

Compound 4, half-maximal inhibitory concentration: 2300 nM
Beside the measured number, compound 4's estimate is 1.5-fold (0.19 log units) below it, and the stated range covers the measured number.
By their numbers in this assay, from the lowest: compound 2; then compound 1; then compounds 4 and 3 (each within the scatter of the next).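

In this assay the exchange of piperidin-1-yl for dipropylamino on a sulfonyl sulfur gives a 1.3-fold lower number from compound 3 to compound 4 (0.10 log units; within the scatter), so the ring and this open-chain group are not separated at this position. The two open-chain groups, by contrast, do separate, with a 2.3-fold higher number from compound 1 to compound 4 (0.36 log units; beyond the scatter); compound 4 therefore goes against reading the earlier step from compound 1 to compound 3 as a simple contrast between open chain and ring, and what matters at this sulfur is narrower than the presence of a ring. Nothing available here gives a measured cause for either step. Still open, from the compounds shown here alone, is whether a shorter chain such as dimethylamino, or a smaller ring such as pyrrolidin-1-yl, would fall with compound 1 or with compound 3. Also open, going by these compounds, is how far this ranking of sulfur substituents carries over to cores other than the ethyl ester.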